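Swapping hydroxymethyl for methoxy on compound 2

The source may report more compounds than this note shows. Statements on the series, on what has been measured and on what is new or still open speak of the compounds shown alone.

Of the compounds shown here, three have been measured in a functional assay on Caco-2 cells (Homo sapiens) for cytotoxicity, read by MTT assay, with a stated time of 48 h (on this read-out higher numbers stand for weaker inhibition and lower numbers for stronger inhibition), so far. Compound 1 `COCCCN1C(/C=C/c2ccc(O)cc2)=CC(=O)CC1c1ccc(O)cc1` returns > 100000 nM in this assay and this is a limit of the assay, not a number. Compound 2 `O=C(/C=C(/C=C/c1ccc(O)cc1)NCCCO)/C=C/c1ccc(O)cc1` gives 31600 nM in this assay and holds the lower of the two actual numbers. Compound 3 `COc1cc(/C=C/C(=O)/C=C(/C=C/c2ccc(O)c(OC)c2)NCCCO)ccc1O` gives 75700 nM in this assay and so lies above compound 2 by a gap beyond the usual scatter.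

Compound 4 `COCCNC(=C\C(=O)/C=C/c1ccc(O)cc1)/C=C/c1ccc(O)cc1` has not yet been measured. It has the same atoms as compound 2, joined differently, and the change is methoxy in place of hydroxymethyl on a saturated chain carbon, two bonds along the chain from an amine nitrogen with methoxy in place of hydroxymethyl on a saturated chain carbon, two bonds along the chain from an amine nitrogen. Among the measured compounds shown here, no measured pair shows this change alone, so the expectation rests on compound 2 at 31600 nM as its starting point. The expected step of a 1.3-fold higher number from compound 2 to compound 4 (0.10 log units; within the scatter) is small, toward a slightly higher number and not clearly beyond the scatter. In this assay compound 4 is estimated at 40000 nM with an expected range from 15000 nM to 100000 nM for this estimate.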

Compound 4, half-maximal inhibitory concentration in the Caco-2 assay: 28000 nM
Compound 4: the middle estimate sits 1.4-fold (0.15 log units) above what was measured; low and high end bracket the measured number.
By their numbers in the Caco-2 assay, from the lowest: compounds 4 and 2 (each within the scatter of the next); then compound 3. At a limit, above all of these: compound 1.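

In the Caco-2 assay the change from (3-hydroxypropyl)amino to (2-methoxyethyl)amino gives a 1.1-fold lower number from compound 2 to compound 4 (0.05 log units; within the scatter), so at this position, on a saturated chain carbon, two bonds along the chain from an amine nitrogen, methoxy and hydroxymethyl cannot be told apart on this read-out. Among the compounds shown here, no earlier pair differed in this one place alone, so this is the only direct reading of the change. The same change does separate the two compounds in a physicochemical assay for solubility, using the shake flask method, in phosphate buffer, with a stated time of 90 min, at pH 6.8 (a lower number here means a less soluble compound, a higher number a more soluble compound), where compound 2 gives 137000 nM and compound 4 gives 37500 nM, so compound 4 is the less soluble: the measured solubility of compound 2, 137000 nM, and of compound 4, 37500 nM, a 3.7-fold lower number (0.56 log units; beyond the scatter)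

From the compounds shown here alone, whether the chain end tolerates groups of another kind, such as an amine or a carboxylic acid, stays open. For the compounds shown here, in the Caco-2 assay compound 1 gives > 100000 nM, which is a limit of the assay and not a number, and it offers no step to set beside this one.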